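One stereocentre inverted: compound 1 to compound 3

This account rests on a few compounds, and the source may have more. Where it says the series, first, only, none or still open, it means among the compounds named here.

Measured in a physicochemical assay for lipophilicity, at pH 7.4 (on this read-out higher numbers stand for higher lipophilicity and lower numbers for lower lipophilicity), so far:
- compound 1 `Cc1cc(C)c(CN2CCc3c(Cl)cc([C@@H](CO)[C@@H]4CCCO4)c(Cl)c3C2=O)c(=O)[nH]1` gives 2.1
- compound 2 `COC(C)c1cc(Cl)c2c(c1Cl)C(=O)N(Cc1c(C)cc(C)[nH]c1=O)CC2` gives 3.3; 3.4 (2 entries)

In this assay, going by the values given here, compound 1 has 2.1 as its only number, and a further entry carries no single number. That value lies lower than those of compound 2 at 3.3; 3.4 (2 entries) on the same scale.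

Compound 3 `Cc1cc(C)c(CN2CCc3c(Cl)cc([C@@H](CO)[C@H]4CCCO4)c(Cl)c3C2=O)c(=O)[nH]1` has the same atoms and bonds as compound 1, and the change is the two compounds have the same atoms and bonds and differ only in configuration as drawn: 1 of 2 stereo elements differ; a stereocentre at a saturated ring carbon is drawn S in compound 1 and R in compound 3 with nothing leaving or entering. Among the compounds with values here, no measured pair shows such a change, so no direction is favoured in this assay and nothing beyond the scatter is expected. The estimated change is no change at the digits printed from compound 1 to compound 3 (within the scatter) in this reading. For compound 3 the estimated value is 2.1 with an expected range from 1.8 to 2.4 overall.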

Compound 3, distribution coefficient: 2.5
Compound 3: middle estimate off by 0.40 log units, on the low side; the measured number lies above the stated range.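

In this assay the configuration at the saturated ring carbon is not silent: drawing it R rather than S gives a number 0.40 log units higher from compound 1 to compound 3 (beyond the scatter) with atoms and bonds unchanged. This is the only step shown that isolates a single stereocentre, and compound 2 differs from compound 1 in more than one place, so it offered no such reading.

From the compounds shown here alone, whether the second stereo element behaves alike remains open. So does whether this inversion gives a step of similar size when an amine or a carboxylic acid is carried on the core of compound 1.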